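This account rests on a few compounds, and the source may have more. Where it says the series, first, only, none or still open, it means among the compounds named here.

Only two close relatives have been tested so far in a functional assay on HCT-116 cells (Homo sapiens) for inhibition, read by CCK-8 assay, with a stated time of 48 h; on this read-out lower numbers stand for stronger inhibition and higher numbers for weaker inhibition. Compound 1 (`COc1ccc(CN(C(=O)CSC(=S)N2CCN(C(=O)OC(C)(C)C)CC2)c2cc(OC)c(OC)c(OC)c2)cc1OC`) reads > 20000 nM, which is a limit of the assay and not a number. Among the compounds with values here, compound 2 (`COc1ccc(CN(C(=O)CSC(=S)N2CCN(C(=O)OC(C)(C)C)CC2)c2cc(OC)c(OC)c(OC)c2)cc1F`) gives 8210 nM, the only true number available, so there is no measured series to rank it against.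

Compound 3 (`COc1ccc(CN(C(=O)CSC(=S)N2CCN(C(=O)OC(C)(C)C)CC2)c2cc(OC)c(OC)c(OC)c2)cc1Br`) alters compound 2 in one place: bromo in place of fluoro on an aromatic carbon. This puts bromo in place of fluoro on an aromatic carbon, ortho to a methoxy group and meta to a large group, turning 3-fluoro-4-methoxybenzyl into 3-bromo-4-methoxybenzyl.

Within the data shown here, one measured step bears on this change, and it concerns the same aromatic carbon: an at least 2.4-fold lower number from compound 1 to compound 2 (0.38 log units; beyond the scatter). It suggests that a swap at this carbon can shift the read-out. However, it compares fluoro with methoxy, and no two halogens have been compared, so it gives no firm direction for the new swap. A small change, possibly none beyond the scatter, is therefore expected in this assay.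

The estimated size of this change is a 1.2-fold lower number from compound 2 to compound 3 (0.07 log units; within the scatter).

The estimate for compound 3 is 7000 nM, with an expected range from 2500 nM to 20000 nM.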

Compound 3, half-maximal inhibitory concentration: 9710 nM
The estimate for compound 3 lay 1.4-fold (0.14 log units) below the measured number; measured number inside the range.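

In this assay, two halogens can now be compared on this aromatic carbon, and the swap gives a 1.2-fold higher number from compound 2 to compound 3 (0.07 log units; within the scatter), so the read-out does not separate fluoro from bromo here. Bromo in place of methoxy at the same carbon gives an at least 2.0-fold lower number from compound 1 to compound 3 (0.31 log units; beyond the scatter), so the earlier step from methoxy to fluoro now has a counterpart with a second, much larger halogen atom, and both halogens read lower than the methoxy compound. The true size of both steps away from compound 1 stays unknown, since the reading of compound 1 is a limit of the assay and not a number: the limit of > 20000 nM in this assay, at which 1 of the 3 values shown sits.

These three compounds cannot show whether a halogen itself matters at this carbon or whether removing the methoxy group is enough, and a plain hydrogen or a methyl group there would help to separate those two readings. As far as these compounds go, it also remains open whether a chloro group fits alongside fluoro and bromo, or whether an amine or a carboxylic acid on this carbon would move the number well away from those of compound 2 and compound 3.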